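The source may hold more compounds than are shown below. What is called first, only, known or untested is meant among the compounds shown, and "the series" means these compounds.

Measured in a functional assay on K562 cells (Homo sapiens) for cytotoxicity, read by sulforhodamine B assay; on this read-out lower numbers stand for higher toxicity in this test and higher numbers for lower toxicity in this test:
- compound 1 `CC1=CC[C@@H]([C@@](C)(O)CCCC(C)(C)NC(=S)NN)CC1`: 9580 nM
- compound 2 `CC1=CC[C@@H]([C@@](C)(O)CCCC(C)(C)NC(=S)N/N=C\c2ccc(C)cc2)CC1`: > 100000 nM

Compound 2 stands at the limit of > 100000 nM in this assay, at which 1 of the 2 values shown sits. From the compounds shown here alone, its entry of > 100000 nM is a limit and not a number, so its true position on the scale is unknown.

The next compound, compound 3 `CC1=CC[C@@H]([C@@](C)(O)CCCC(C)(C)NC(=S)N/N=C\c2ccccc2[N+](=O)[O-])CC1`, differs from compound 2 in one place: 2-nitrophenyl in place of 4-methylphenyl on a carbon with a double bond to nitrogen. In short, 2-nitrophenyl takes the place of 4-methylphenyl on a carbon with a double bond to nitrogen.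

For the measured compounds named here, only one measured step bears on this change. It is the large step of an at least 10-fold higher number from compound 1 to compound 2 (1.01 log units; beyond the scatter), in which the group carrying the aromatic ring came in. Compound 3 keeps an aromatic ring on that same carbon, so it is expected to stay on the high-number side, well away from compound 1. Going by the values given here, no measured step tests a swap of one aromatic group for another, so the expectation is loose. A further reading at the limit is about as likely as a measurable number.

The estimated change is modest and toward a lower number: an at least 1.6-fold lower number from compound 2 to compound 3 (0.22 log units; that floor lies within the scatter).

In this assay the expected value for compound 3 is 60000 nM, with an estimated range from 15000 nM to 150000 nM.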

Compound 3, concentration lethal to 50% of the cells: > 100000 nM
Compound 3 gave a limit, no number (the forecaster's own chance of this, stated with the estimate: 50%); at least 1.6-fold (0.22 log units) between middle value and limit.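

In this assay, compound 2 and compound 3 both give a limit and not a number, so the step between them cannot be read and no new step follows: the limit of > 100000 nM in this assay, at which 2 of the 3 values shown sit.

The compounds shown leave open where compound 2 and compound 3 truly lie on the scale, and whether 2-nitrophenyl in place of 4-methylphenyl changes the read-out at all.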